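Swapping the ring substituent in a bile acid receptor series

The compounds below may be only part of what the source reports. "The series", "measured", "known", "first", "only" and "open" are said of these compounds alone.

Of the compounds shown here, three share one core and have been tested in an assay on isolated protein for agonist activity at Bile acid receptor (Homo sapiens), read by AlphaScreen, with a stated time of 30 min; a higher number here means that more compound is needed for the effect, a lower number that less compound is needed. Compound 1 `Cc1nn(-c2ccccc2C(C)C)c2c1[C@@H](c1ccc(Oc3ccccc3)cc1)S[C@@H](C)C(=O)N2` gives 1900 nM. Compound 3 `Cc1nn(-c2ccccc2I)c2c1C(c1ccc(Oc3ccccc3)cc1)SC(C)C(=O)N2` gives 1300 nM. Compound 2 `CCOc1cccc(-c2ccc([C@H]3S[C@@H](C)C(=O)Nc4c3c(C)nn4-c3ccccc3C)cc2)c1` gives 3500 nM, the highest of the three numbers; its gap to compound 1 lies within the usual scatter, while its gap to compound 3 lies beyond it.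

Compound 4 `COc1ccccc1Oc1ccc([C@H]2S[C@@H](C)C(=O)Nc3c2c(C)nn3-c2ccccc2C)cc1` is not yet measured. It differs from compound 2 in one place: 2-methoxyphenoxy in place of 3-ethoxyphenyl on an aromatic carbon. The 3-ethoxyphenyl group leaves and a 2-methoxyphenoxy group enters, with one hydrogen-bond acceptor more.

Going by the values given here, no measured pair with exactly this change exists, so the expectation rests on the spread of the three numbers. A modest step down in this assay is expected from compound 2 to compound 4, a 1.9-fold lower number from compound 2 to compound 4 (0.29 log units; within the scatter), though it may stay within the scatter. Compound 4 is estimated at 1800 nM, with a range from 700 nM to 4500 nM, because compound 1 gives 1900 nM and compound 3 gives 1300 nM.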

Compound 4, half-maximal effective concentration: 1700 nM
The estimate for compound 4 lay 1.1-fold (0.02 log units) above the measured number, and the stated range covers the measured number.
By their numbers in this assay, from the lowest: compounds 3, 4, 1 and 2 (each within the scatter of the next, the first and the last beyond it).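

Going by these compounds alone, this is the first comparison in the set in which only one place changes. On an aromatic carbon para to a large group, 2-methoxyphenoxy in place of 3-ethoxyphenyl gives, in this assay, a 2.1-fold lower number from compound 2 to compound 4 (0.31 log units; beyond the scatter), a modest step that lies beyond the scatter. Both groups have 9 heavy atoms and one six-membered aromatic ring of carbon only, but the entering group has 2 hydrogen-bond acceptors where the leaving group has 1, and no measurement here explains the step.

This single swap alters the link to the ring, the place of the ring's substituent and the length of its chain all at once, so the compounds shown cannot assign the step to any one of these. On these data alone, how an amine or a carboxylic acid in place of the methoxy group would read in this assay also remains open.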